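The source may report more compounds than this note shows. Statements on the series, on what has been measured and on what is new or still open speak of the compounds shown alone.

Measured so far:
compound 1, `COc1ccccc1/C=C/C(=O)/C=C/c1ccc(OCc2cn(CCOc3cc(=O)oc4ccccc34)nn2)c(OC)c1` — 67%
compound 2, `COc1cc(/C=C/C(=O)/C=C/c2cc(OC)c(OC)c(OC)c2)ccc1OCc1cn(CCCOc2cc(=O)oc3ccccc23)nn1` — 74%
compound 3, `COc1cc(/C=C/C(=O)/C=C/c2ccco2)ccc1OCc1cn(CCCCOc2cc(=O)oc3ccccc23)nn1` — 43%

All three numbers come from a functional assay on COLO 205 cells (Homo sapiens) for inhibition, read by sulforhodamine B assay, with a stated time of 48 h, tested at 50 uM; on this read-out lower numbers stand for less inhibition of growth and higher numbers for more inhibition of growth at the one concentration tested. Compound 1 stands second highest of the three. Its nearest neighbour is compound 2, whose number lies higher but within the usual scatter of this read-out, so no order between compound 1 and compound 2 can be claimed. The furthest is compound 3, whose number lies lower by a margin beyond the scatter, so compound 3 does show less growth inhibition than compound 1.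

Compound 4, `COc1cccc(/C=C/C(=O)/C=C/c2ccc(OCc3cn(CCOc4cc(=O)oc5ccccc45)nn3)c(OC)c2)c1`, has not yet been measured in this assay. It differs from compound 1 in one place: 3-methoxyphenyl in place of 2-methoxyphenyl on a double-bonded chain carbon bound to a double-bonded chain carbon. Going by the values given here, no measured pair in the set isolates such a change, so there is no step to lean on. With the rest of the molecule kept, the change gives no reason to expect a move beyond the scatter in either direction, and the step of a number 2 percentage points lower from compound 1 to compound 4 (within the scatter) is expected to be small. Compound 4 is therefore estimated at 65%, with a range from 50% to 80%.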

Compound 4, percent growth inhibition at one concentration: 69%
Compound 4: the middle estimate sits 4 percentage points below what was measured, and the stated range covers the measured number.
By their numbers in this assay, from the lowest: compound 3; then compounds 1, 4 and 2 (each within the scatter of the next).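

Going by these compounds alone, the pair gives the first one-place comparison in this assay: 3-methoxyphenyl in place of 2-methoxyphenyl on a double-bonded chain carbon bound to a double-bonded chain carbon gives a number 2 percentage points higher from compound 1 to compound 4 (within the scatter) at the one concentration tested. Within the data shown here, at this place, then, the two methoxyphenyl groups cannot be told apart on growth inhibition, and the swap is the only evidence so far on this position, resting on a single pair with the rest of the molecule kept. Nothing available bears on why the two read alike.

Open, as far as these compounds go, is whether an amine or a carboxylic acid in place of 3-methoxyphenyl at this place would stay within the scatter of compound 4. Also open, from the compounds shown here alone, is whether the same methoxyphenyl swap reads alike on a core with a longer chain.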